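Chain Extension on a Cyclopropylphenyl Thiazolidinone Amide

The source may hold more compounds than are shown below. What is called first, only, known or untested is meant among the compounds shown, and "the series" means these compounds.

The study concerns a small set of thiazolidinone amides tested in a functional assay on HOS-TE85 cells (Homo sapiens) for inhibition, read by CCK-8 assay, with a stated time of 72 h; on this read-out lower numbers stand for stronger inhibition and higher numbers for weaker inhibition. Compound 1 `COc1ccc(OC)c(N2C(=O)CSC2c2cccc(C(=O)NCCCCc3ccccc3)c2)c1` carries a 2,5-dimethoxyphenyl on the amide-type nitrogen in the ring. In this assay compound 1 reaches only the limit of > 1000 nM. Compound 2 `COc1cc(F)ccc1N1C(=O)CSC1c1cccc(C(=O)NCCCCc2ccccc2)c1` differs by 4-fluoro-2-methoxyphenyl in place of 2,5-dimethoxyphenyl on that nitrogen, and in this assay compound 2 gives 71.1 nM; the step of an at least 14-fold lower number from compound 1 to compound 2 (1.14 log units; beyond the scatter) is the only measured one. Compound 3 `O=C(NCCCc1ccccc1)c1cccc(C2SCC(=O)N2c2ccc(C3CC3)cc2)c1` carries a cyclopropylphenyl on the ring nitrogen and a 3-phenylpropyl amide chain. In this assay compound 3 is reported only as a limit, > 1000 nM, so it sits with compound 1 at the limit of > 1000 nM in this assay, at which 2 of the 3 values shown sit.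

The unmeasured compound 4 `O=C(NCCCCc1ccccc1)c1cccc(C2SCC(=O)N2c2ccc(C3CC3)cc2)c1` differs from compound 3 by benzyl in place of phenyl on a saturated chain carbon, three bonds along the chain from an amide-type nitrogen, which read one bond further out is 3-phenylpropyl to 4-phenylbutyl. Within the data shown here, no measured step concerns this chain change; the step from compound 1 to compound 2 varies the ring nitrogen aryl and does not bear on it. Compounds 1 and 2 show that the 4-phenylbutyl chain is compatible with both a limit and a measured number. Compound 4 is therefore expected near the limit, with the step that the limit leaves unreadable from compound 3 to compound 4 uncertain in direction. The estimate for compound 4 is 1500 nM, between 300 nM and 6000 nM.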

Compound 4, half-maximal inhibitory concentration: 217 nM
Beside the measured number, compound 4's estimate is 6.9-fold (0.84 log units) above it; the measured number lies below the stated range.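

In this assay, among these compounds, lengthening the chain from 3-phenylpropyl to 4-phenylbutyl gives an at least 4.6-fold lower number from compound 3 to compound 4 (0.66 log units; beyond the scatter) on the 4-cyclopropylphenyl compounds, the first measured step at this position, and one that lies beyond the scatter. The result also shows that 4-cyclopropylphenyl on the ring nitrogen can give a measured number when the 4-phenylbutyl chain is present, where the earlier pair of compounds on that chain had shown only the effect of changing one aryl group for another. With that chain held constant, the aryl groups now fall into an order, with 4-cyclopropylphenyl giving an at least 4.6-fold lower number from compound 1 to compound 4 (0.66 log units; beyond the scatter) against 2,5-dimethoxyphenyl, yet a 3.1-fold higher number from compound 2 to compound 4 (0.48 log units; beyond the scatter) against 4-fluoro-2-methoxyphenyl, which therefore remains the best of the three on this read-out.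

On these data alone, whether a longer chain such as 5-phenylpentyl, or an amine placed on the chain, would lower the number further remains open, as does whether 4-fluoro-2-methoxyphenyl responds to the chain change in the same way. The full size of the step at the chain also stays unknown, since compound 3 is reported only as a limit: the limit of > 1000 nM in this assay, at which 2 of the 4 values shown sit.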